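This account rests on a few compounds, and the source may have more. Where it says the series, first, only, none or still open, it means among the compounds named here.

In a functional assay on HCT-116 cells (Homo sapiens) for cytotoxicity, read by fluorescence, with a stated time of 72 h (a higher number here means a weaker inhibitor, a lower number a stronger inhibitor), the measured compounds read as follows.

- compound 1 `CC(C)c1n[nH]c2c(NCc3ccc(-c4ccccn4)cc3)nc(NCC(C)(C)O)nc12` gives 85 nM
- compound 2 `CC(C)c1n[nH]c2c(NCc3ccc(-c4ccccn4)cc3)nc(N3CCCCC3CCO)nc12` gives 142 nM
- compound 3 `CC(C)c1n[nH]c2c(NCc3ccc(-c4ccccn4)cc3)nc(N[C@@H]3CCCC[C@H]3N)nc12` gives 427 nM

Compound 3 has the highest number of the three, which makes it the weakest inhibitor here, and its gaps to both others lie beyond the scatter. The next compound, compound 4 `CC(C)c1n[nH]c2c(NCc3ccc(-c4ccccn4)cc3)nc(N3CCNCC3)nc12`, keeps the shared core and alters one group. The change is piperazin-1-yl in place of (2-aminocyclohexyl)amino on an aromatic carbon and it sits on an aromatic carbon between two ring nitrogen atoms.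

All three measured steps concern this same carbon. The closest guide is compound 2, which also carries a six-membered non-aromatic ring there, and its step is a 3.0-fold higher number from compound 2 to compound 3 (0.48 log units; beyond the scatter). Read backwards, that step hints that a ring in this place may bring the number down. The step of a 5.0-fold higher number from compound 1 to compound 3 (0.70 log units; beyond the scatter) is of similar modest size, while a 1.7-fold higher number from compound 1 to compound 2 (0.22 log units; within the scatter) shows that two quite different groups can give matching values. For the measured compounds named here, no measured compound carries piperazin-1-yl, so this guide is only a rough one.

The expected change in this assay is therefore a small drop, estimated as a 1.7-fold lower number from compound 3 to compound 4 (0.23 log units; within the scatter). For compound 4 the estimated value is 250 nM, with an expected range from 100 nM to 700 nM.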

Compound 4, half-maximal inhibitory concentration: 88 nM
Compound 4: middle estimate off by 2.8-fold (0.45 log units), on the high side; the measured number lies below the stated range.
By their numbers in this assay, from the lowest: compounds 1, 4 and 2 (each within the scatter of the next); then compound 3.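

In this assay, piperazin-1-yl in place of (2-aminocyclohexyl)amino gives a 4.9-fold lower number from compound 3 to compound 4 (0.69 log units; beyond the scatter), so having a six-membered non-aromatic ring in this group does not by itself set the value, since both groups carry one. The other two new steps, a 1.6-fold lower number from compound 2 to compound 4 (0.21 log units; within the scatter) and a 1.0-fold higher number from compound 1 to compound 4 (0.02 log units; within the scatter), are within the scatter, which puts three quite different groups on this aromatic carbon level with one another, one of them an open chain, and leaves compound 3 as the only one of the four apart from the rest. Nothing shown here accounts for why compound 3 stands apart.

The compounds shown leave open whether the second ring nitrogen of piperazin-1-yl matters at all, a question that morpholin-4-yl, with oxygen in that place, or 4-methylpiperazin-1-yl, with a methyl on that nitrogen, could help to answer. They also leave open whether the result for compound 3 is tied to its two defined stereocentres, which the other stereoisomers of the (2-aminocyclohexyl)amino group could settle.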